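A few compounds are considered here, and "the series" means these few. Any claim that something is new, unique, unknown or untested is made for them only; others in the source may bear on it.

Measured so far:
compound 1, `CCOc1ncccc1-c1c(C)nn(-c2nc(-c3ccc(Cl)c(Cl)c3)c(SC(C)C)s2)c1C(=O)O`, 11000 nM
compound 2, `COC(=O)c1c(Cc2ccccc2[N+](=O)[O-])c(C)nn1-c1nc(-c2ccc(Cl)c(Cl)c2)c(SC(C)C)s1`, 93000 nM

In a functional assay on BJAB cells (Homo sapiens) for antiproliferative activity, with a stated time of 4 days (a lower number here means that less compound is needed, a higher number that more compound is needed for the effect), compound 1 stands with the lowest of the two numbers, and compound 2 gives a number well beyond the scatter above it. Going by the values given here, no step between measured compounds that differ in only one place is known, so the next change has no direct precedent. Compound 3, `Cc1cc(Cl)cc(-c2c(C)nn(-c3nc(-c4ccc(Cl)c(Cl)c4)c(SC(C)C)s3)c2C(=O)O)c1`, differs from compound 1 in one place: 3-chloro-5-methylphenyl in place of 2-ethoxypyridin-3-yl on an aromatic carbon. Against this background a small step is expected in this assay, not clearly beyond the scatter in either direction. Compound 3 is therefore expected to give about 8000 nM, within a range from 2500 nM to 25000 nM. This estimate means an expected step of a 1.4-fold lower number from compound 1 to compound 3 (0.14 log units; within the scatter).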

Compound 3, half-maximal effective concentration: 663 nM
Estimate against measurement, compound 3: 12-fold (1.08 log units) above, and the stated range ends above it.
By their numbers in this assay, from the lowest: compound 3; then compound 1; then compound 2.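

In this assay, the group at this position of the shared core clearly matters: 3-chloro-5-methylphenyl in place of 2-ethoxypyridin-3-yl gives a 17-fold lower number from compound 1 to compound 3 (1.22 log units; beyond the scatter) for a single change. A six-membered aromatic ring of carbon only, with no hydrogen-bond acceptors, is therefore well accepted here. No available measurement explains the step. Because this one swap changes several things at once, the compounds leave open whether the chlorine, the methyl or the loss of ethoxy and ring nitrogen counts most. A plain phenyl, or an amine on that ring, could help separate these.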